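Swapping Trifluoromethyl for Acetyl on the Aryl Amide

The source may hold more compounds than are shown below. What is called first, only, known or untested is meant among the compounds shown, and "the series" means these compounds.

Three compounds share one core, shown in compound 1 `O=C(/C=C/[C@H]1C[C@@H](O)[C@@H](O)C1)Nc1ccc(Cl)c(Cl)c1`, compound 2 `O=C(/C=C/[C@H]1C[C@@H](O)[C@@H](O)C1)Nc1ccc(F)cc1` and compound 3 `O=C(/C=C/[C@H]1C[C@@H](O)[C@@H](O)C1)Nc1ccc(C(F)(F)F)cc1`, and differ only in the groups carried on the aromatic ring attached to the amide. In an ADME assay on S2 cells (Drosophila melanogaster) for cytotoxicity, read by MTT assay (a higher number here means that more compound is needed for the effect, a lower number that less compound is needed), compound 1 gives > 160000 nM, which is a limit of the assay rather than a number. Compound 2 likewise gives > 180000 nM, again a limit. Compound 3 gives > 160000 nM, also a limit. Compound 3 therefore stands at the limit of > 160000 nM in this assay, at which 2 of the 3 values shown sit, while compound 2 stands at the limit of > 180000 nM in this assay, at which 1 of the 3 values shown sits. Going by the values given here, the one measured step, a step that the two limits leave unreadable from compound 2 to compound 3, cannot be read, since both of its ends are limits. Compound 4 `CC(=O)c1ccc(NC(=O)/C=C/[C@H]2C[C@@H](O)[C@@H](O)C2)cc1` carries acetyl in place of trifluoromethyl on an aromatic carbon. Among the compounds with values here, no measured step bears on this change, and none of the three values offers a number to build on. The expectation for compound 4 is that it too gives only a limit, with the step that the limit leaves unreadable from compound 3 to compound 4 expected to stay within the scatter. The estimate for compound 4 is 200000 nM, with a range from 100000 nM to 400000 nM.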

Compound 4, half-maximal effective concentration: > 180000 nM
Compound 4: only a limit was reported; the forecaster's own chance of this, stated with the estimate: 90%; the middle value lies beyond the limit too.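

Compound 4, like compound 3 and compound 2, gives only a limit of the assay, so neither step leading to compound 4 can be read. As far as these compounds go, what stays open is the concentration at which any of compound 1, compound 2, compound 3 or compound 4 takes effect in this assay, and whether the groups on the aromatic ring shift it at all.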